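A Bromophenyl Swap on a Shared Core

A few compounds are considered here, and "the series" means these few. Any claim that something is new, unique, unknown or untested is made for them only; others in the source may bear on it.

Compound 1, `Cc1cc(Nc2cc(-c3ccccc3)[nH]n2)n2nc(SCc3cccc(Br)c3)nc2n1`: in a functional assay on PC-9 cells (Homo sapiens) for inhibition, read by MTT assay, with a stated time of 72 h (a lower number here means a stronger inhibitor, a higher number a weaker inhibitor), compound 1 gives 8900 nM.
Compound 2, `Cc1cc(Nc2ccn(Cc3nc(C)c4ccccc4n3)n2)n2nc(SCc3ccc(Br)cc3)nc2n1`: compound 2 gives 5450 nM.
Compound 3, `Cc1cc(Nc2ccn(Cc3ccc(C(F)(F)F)cc3)n2)n2nc(SCc3ccc(Br)cc3)nc2n1`: compound 3 gives 5580 nM.

Compound 1 carries the largest of the three numbers, but its distance to compound 3 and its distance to compound 2 both fall within the scatter, so the three compounds cannot be separated on these data.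

Compound 4, `Cc1cc(Nc2cc(-c3ccccc3)[nH]n2)n2nc(SCc3ccc(Br)cc3)nc2n1`, has not yet been measured. It differs from compound 1 by a single rearrangement: 4-bromophenyl in place of 3-bromophenyl on a saturated chain carbon bound to a sulfur.

Among the measured compounds shown here, only one measured step is available, a 1.0-fold higher number from compound 2 to compound 3 (0.01 log units; within the scatter), and it concerns a different position on the shared core, so it does not speak to the present change. For the measured compounds named here, compounds 2 and 3 both carry the 4-bromophenyl that enters in compound 4, yet each differs from compound 1 elsewhere as well, so no measured pair isolates this change. With nothing pointing either way, the expectation for compound 4 is a step of a 1.1-fold lower number from compound 1 to compound 4 (0.05 log units; within the scatter) that stays within the scatter.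

Compound 4 is therefore estimated at 8000 nM, with a range from 3000 nM to 20000 nM.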

Compound 4, half-maximal inhibitory concentration: 4760 nM
For compound 4 the middle estimate is 1.7-fold (0.23 log units) above the measured one, and the stated range covers the measured number.
By their numbers in this assay, from the lowest: compounds 4, 2, 3 and 1 (each within the scatter of the next).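

Among the compounds shown here, the pair of compound 1 and compound 4 gives the first direct reading of this position, since the two share everything except the placement of the bromine on the group attached to the saturated chain carbon bound to a sulfur. In this assay, 4-bromophenyl in place of 3-bromophenyl gives a 1.9-fold lower number from compound 1 to compound 4 (0.27 log units; within the scatter), so the two bromophenyl groups cannot be told apart on this read-out. No supporting data are available to account for this result, whether as a real difference or as none.

Going by these compounds, what a 4-chlorophenyl, a 4-methoxyphenyl or a plain phenyl would give on that same carbon remains open, as does the outcome with a group of a different kind there, such as an amine or a carboxylic acid. It is also open whether the swap would give a similar step on the substituted cores of compound 2 and compound 3, since neither has a 3-bromophenyl partner among the compounds shown.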